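The compounds below may be only part of what the source reports. "The series", "measured", "known", "first", "only" and "open" are said of these compounds alone.

The measured compounds: compound 1 `CN1CCC[C@H]1COc1cncc(O)c1`, 3.7 nM; compound 2 `Oc1cncc(OC[C@@H]2CCCN2)c1`, 2.5 nM; compound 3 `COc1ccccc1OC[C@@H]1CCCN1`, 53500 nM.

All three were tested in an assay on cell membranes for displacement of a labelled ligand from Neuronal acetylcholine receptor; alpha4/beta2 (Rattus norvegicus), read by scintillation counting; a higher number here means a weaker inhibitor, a lower number a stronger inhibitor. Compounds 1 and 2 share a core, and the step of a 1.5-fold higher number from compound 2 to compound 1 (0.17 log units; within the scatter) came from the change (methyl in place of hydrogen on an amine nitrogen in a ring). Compound 3 is built on a different core; the difference between the two cores is not broken down here, and in this assay compound 3 gives 53500 nM, far higher than either of the others.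

Compound 4 `COc1ccccc1OC[C@@H]1CCCN1C` has not yet been measured. It is related to compound 3 by methyl in place of hydrogen on an amine nitrogen in a ring. Going by the values given here, this is the same kind of change as the one from compound 2 to compound 1, though here the place is next to the ring atom that bears a large group, whereas in compound 2 it is next to the ring atom that bears a group of 9 heavy atoms. Because the earlier step of a 1.5-fold higher number from compound 2 to compound 1 (0.17 log units; within the scatter) lay within the scatter, compound 4 is expected to stay close to compound 3, with an expected step of a 1.5-fold higher number from compound 3 to compound 4 (0.17 log units; within the scatter). The estimate for compound 4 in this assay is 80000 nM, expected to fall between 20000 nM and 300000 nM.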

Compound 4, inhibition constant: 9400 nM
Estimate against measurement, compound 4: 8.5-fold (0.93 log units) above; the measured number lies below the stated range.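

Methyl in place of hydrogen on an amine nitrogen in a ring gave a 5.7-fold lower number from compound 3 to compound 4 (0.76 log units; beyond the scatter) in this assay on the core of compound 3, so this change did not carry over with the same size from the other core. The two steps differ, and the gap is larger than repeated measurements would account for: the same change on two cores in this assay, a 1.5-fold higher number (0.17 log units; within the scatter) from compound 2 to compound 1 and a 5.7-fold lower number (0.76 log units; beyond the scatter) from compound 3 to compound 4, 8.4-fold (0.93 log units) apart, beyond the scatter of two such steps. Going by these compounds alone, this shows that, in these two pairs, the step measured on one core did not predict the step on the other, but with only two pairs it neither gives a rule for other cores nor tells which feature of the cores accounts for the difference.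

The compounds shown leave open whether an ethyl group or a longer chain on the same nitrogen would follow the step seen on either core. They also leave open whether the step would stay the same on a core that differs from the core of compound 3 in only one place, for example with a chlorine atom in place of its methoxy group.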